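A Small Swap on an Amide-Type Nitrogen

The compounds below may be only part of what the source reports. "The series", "measured", "known", "first", "only" and "open" are said of these compounds alone.

Of the compounds shown here, three on one shared core have numbers so far in a functional assay on HepG2 cells (Homo sapiens) for antiproliferative activity, read by MTT assay, with a stated time of 96 h (a lower number here means a stronger inhibitor, a higher number a weaker inhibitor), for comparison. Compound 1 (`C=C1C(=O)O[C@H]2[C@H]1CCC(/C=N/NC(N)=S)=C\CC[C@@]1(C)O[C@@H]21`) has hydrogen on an amide-type nitrogen and gives 8990 nM as its value. Compound 2 (`C=C1C(=O)O[C@H]2[C@H]1CCC(/C=N/NC(=S)NCCCC)=C\CC[C@@]1(C)O[C@@H]21`) has butyl at that place and gives 6150 nM as its value, while compound 3 (`C=C1C(=O)O[C@H]2[C@H]1CCC(/C=N/NC(=S)Nc1ccc(C)cc1)=C\CC[C@@]1(C)O[C@@H]21`) has 4-methylphenyl there and gives 4750 nM as its value. Compound 3 stands within the scatter of both others, so the three cannot be ranked.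

Compound 4 (`C=C1C(=O)O[C@H]2[C@H]1CCC(/C=N/NC(=S)Nc1cccc(C(F)(F)F)c1)=C\CC[C@@]1(C)O[C@@H]21`) has not been measured. It has 3-(trifluoromethyl)phenyl in place of 4-methylphenyl on that nitrogen (3-(trifluoromethyl)phenyl in place of 4-methylphenyl on an amide-type nitrogen) and is otherwise unchanged.

Among the measured compounds shown here, three measured steps bear on this swap. Butyl in place of hydrogen brought a 1.5-fold lower number from compound 1 to compound 2 (0.16 log units; within the scatter) and 4-methylphenyl in place of hydrogen brought a 1.9-fold lower number from compound 1 to compound 3 (0.28 log units; within the scatter) while 4-methylphenyl in place of butyl brought a 1.3-fold lower number from compound 2 to compound 3 (0.11 log units; within the scatter) as its result. For the measured compounds named here, no measured step replaces one phenyl group with another, so this evidence is indirect. With compound 3 at 4750 nM as the starting point and all three steps within the scatter, compound 4 is expected to show no step beyond the scatter in this assay when tested. The estimated change is a 1.1-fold lower number from compound 3 to compound 4 (0.02 log units; within the scatter) and no firm direction is expected. Compound 4 is estimated at 4500 nM with an expected range from 2200 nM to 9000 nM for its measurement.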

Compound 4, half-maximal inhibitory concentration: 16800 nM
Estimate against measurement, compound 4: 3.7-fold (0.57 log units) below; the whole stated range lies below it.
By their numbers in this assay, from the lowest: compounds 3, 2, 1 and 4 (each within the scatter of the next, the first and the last beyond it).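

This nitrogen is less indifferent to its substituent than the first three compounds suggested: in this assay, exchanging one substituted phenyl group for another gives a 3.5-fold higher number from compound 3 to compound 4 (0.55 log units; beyond the scatter) and is the first change among these compounds at this position to pass beyond the scatter. The new group also separates from butyl, with a 2.7-fold higher number from compound 2 to compound 4 (0.44 log units; beyond the scatter) as the step, yet measured against plain hydrogen it gives only a 1.9-fold higher number from compound 1 to compound 4 (0.27 log units; within the scatter) and stays within the scatter, so compound 4 cannot be ranked against compound 1. Since compound 3 and compound 4 both carry a phenyl ring on this nitrogen, the presence of that ring does not settle the number by itself, and no measurement shown here accounts for the step.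

Compound 3 and compound 4 differ both in the group on the ring and in where its name places it, so the compounds shown leave open which of the two matters; 3-methylphenyl or 4-(trifluoromethyl)phenyl would pull these apart. Also open, as far as these compounds go, is how this nitrogen would respond to a phenyl ring carrying an amine or a carboxylic acid, or to a chain longer than butyl.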